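The compounds below may be only part of what the source reports. "The series", "measured", "known", "first", "only" and "open" are said of these compounds alone.

Compound 3 `N#CC1=C(N)N(c2ccc(S(N)(=O)=O)cc2)C2=C(CCCC2)C1c1ccc([N+](=O)[O-])cc1` gives 5% in a functional assay on Ehrlich cells (Mus musculus) for cytotoxicity, read by trypan blue exclusion, with a stated time of 2 h, tested at 25 ug/mL (on this read-out higher numbers stand for a stronger effect at the one concentration tested and lower numbers for a weaker effect), the lowest of the three numbers: compound 1 `N#CC1=C(N)N(c2ccc(S(N)(=O)=O)cc2)C2=C(CCCC2)C1c1ccccc1O` gives 40% and compound 2 `N#CC1=C(N)N(c2ccc(S(N)(=O)=O)cc2)C2=C(CCCC2)C1c1ccc(O)cc1` gives 42%, while a number 2 percentage points higher from compound 1 to compound 2 (within the scatter). Compound 4 `N#CC1=C(N)N(c2ccc(S(N)(=O)=O)cc2)C2=C(CCCC2)C1c1c(O)ccc2ccccc12` has not yet been measured; it differs from compound 3 by 2-hydroxynaphthalen-1-yl in place of 4-nitrophenyl on a saturated ring carbon. Within the data shown here, two measured steps bear on this change, a number 35 percentage points lower from compound 1 to compound 3 (beyond the scatter) and a number 37 percentage points lower from compound 2 to compound 3 (beyond the scatter), and both run in the opposite sense to the step now in question, since each brought in the nitro group that compound 4 does not carry. Reversing a step of that size, compound 4 is expected to show a number 35 percentage points higher from compound 3 to compound 4 (beyond the scatter), an upward step beyond the scatter. The estimate for compound 4 is 40%, with a range from 20% to 60%.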

Compound 4, a percentage reported as activity, at one concentration (the size of the read-out at that concentration, not a potency): 5%
The estimate for compound 4 lay 35 percentage points above the measured number, and the stated range ends above it.
By their numbers in this assay, from the lowest: compounds 3 and 4 (each within the scatter of the next); then compounds 1 and 2 (each within the scatter of the next).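

In this assay, a hydroxy group on the aryl substituent at this saturated ring carbon proved insufficient to sustain the read-out: the record shows no change at the digits printed from compound 3 to compound 4 (within the scatter), alongside a number 37 percentage points lower from compound 2 to compound 4 (beyond the scatter) and a number 35 percentage points lower from compound 1 to compound 4 (beyond the scatter). Removing the nitro group therefore did not by itself restore the number, as 2-hydroxynaphthalen-1-yl stayed level with 4-nitrophenyl. No available evidence accounts for this result. As far as these compounds go, what remains open is whether an amine or a carboxylic acid on the phenyl ring at this carbon would align with the hydroxyphenyl compounds or with compound 3 and compound 4.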